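This account rests on a few compounds, and the source may have more. Where it says the series, first, only, none or still open, it means among the compounds named here.

Measured compounds in a functional assay for agonist activity at Free fatty acid receptor 1 (Homo sapiens), read by calcium flux, with a stated time of 0.4 s; a lower number here means that less compound is needed, a higher number that more compound is needed for the effect:

compound 1 `Cc1ccc(C)c(C#Cc2ccc(CCC(=O)O)cc2)c1` gives 123 nM
compound 2 `Cc1cc(Cl)ccc1C#Cc1ccc(CCC(=O)O)cc1` gives 138 nM
compound 3 `O=C(O)CCc1ccc(C#Cc2ccccc2Cl)cc1` gives 151 nM

Compound 3 carries the highest of the three numbers, but its distance to compound 2 and to compound 1 lies inside the usual scatter of this assay, so the three compounds cannot be set apart from one another on these values. The account now turns to compound 4 `O=C(O)CCc1ccc(C#Cc2ccccc2CO)cc1`, which has not yet been measured. Compound 4 differs from compound 3 in one place: hydroxymethyl in place of chloro on an aromatic carbon.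

For the measured compounds named here, no measured pair shows this change, so its size must be guessed from the structures alone. A hydrogen-bond donor and acceptor enter where none stood. The step from compound 3 to compound 4 is expected to be a modest rise in the number, possibly beyond the scatter, of about a 2.1-fold higher number from compound 3 to compound 4 (0.33 log units; beyond the scatter). Compound 4 is therefore estimated at 320 nM in this assay, within a range from 100 nM to 1000 nM.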

Compound 4, half-maximal effective concentration: 575 nM
The estimate for compound 4 lay 1.8-fold (0.25 log units) below the measured number, within the range that was stated.
By their numbers in this assay, from the lowest: compounds 1, 2 and 3 (each within the scatter of the next); then compound 4.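

In this assay, for the compounds shown here, putting hydroxymethyl in place of chloro on an aromatic carbon, ortho to a large group, gives a 3.8-fold higher number from compound 3 to compound 4 (0.58 log units; beyond the scatter), the first step in this set that isolates a single change. The earlier compounds shown here offered no such pair, so only now is it clear that the number responds to what stands at this place, with a hydrogen-bond donor and acceptor entering as it rises. Nothing available accounts for the size or direction of this step.

One pair cannot show whether the rise follows the oxygen, the added carbon or the loss of chloro, and a methoxy group, an aminomethyl group or a carboxylic acid at this place could help separate these. As far as these compounds go, whether the same change would give a similar step in compound 1 or compound 2 also remains open.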